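This account rests on a few compounds, and the source may have more. Where it says the series, first, only, none or still open, it means among the compounds named here.

Measured so far in a functional assay on U-937 cells (Homo sapiens) for antiproliferative activity, read by CCK-8 assay, with a stated time of 24 h (on this read-out higher numbers stand for weaker inhibition and lower numbers for stronger inhibition), for two compounds:
- compound 1 `CN(C)Cc1ccc2nc(NC(=O)N/N=C/c3ccccn3)sc2c1` gives 23200 nM
- compound 2 `C/C(=N\NC(=O)Nc1nc2ccc(CN(C)C)cc2s1)c1ccccn1` gives 20100 nM

Compound 1 and compound 2 lie within the scatter of each other, so compound 1 holds no separate place on these two numbers. Compound 3 `CCN(CC)Cc1ccc2nc(NC(=O)N/N=C/c3ccccn3)sc2c1` keeps the core of compound 1, with diethylamino in place of dimethylamino on a saturated chain carbon bound to an aromatic carbon. Among the measured compounds shown here, no measured pair shows this change, so no step beyond the scatter is expected in this assay. The estimated step of a 1.3-fold lower number from compound 1 to compound 3 (0.11 log units; within the scatter) points, if anywhere, to a slightly lower number. The expected value for compound 3 is 18000 nM (estimated range 8000 nM to 40000 nM).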

Compound 3, half-maximal inhibitory concentration: 24800 nM
Compound 3: middle estimate off by 1.4-fold (0.14 log units), on the low side; low and high end bracket the measured number.
By their numbers in this assay, from the lowest: compounds 2, 1 and 3 (each within the scatter of the next).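

In this assay, among the compounds shown here, diethylamino in place of dimethylamino on a saturated chain carbon bound to an aromatic carbon gives a 1.1-fold higher number from compound 1 to compound 3 (0.03 log units; within the scatter) and is the first step read at this position. On this single pair, enlarging the amine from dimethylamino to diethylamino leaves the number within the scatter. No supporting measurement bears on this result.

On these data alone, whether a morpholine, a piperidine or a carboxylic acid at this place would move the number beyond the scatter stays open. Also open, as far as these compounds go, is whether the same change gives a similar step on compound 2.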